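Compound 3: exchanging the aryl substituent on the biphenyl acid

This account rests on a few compounds, and the source may have more. Where it says the series, first, only, none or still open, it means among the compounds named here.

The series is assessed in an assay on mitochondria (strain BALB/c) for inhibition of glycerol-3-phosphate acyltransferase 1, mitochondrial (Mus musculus), read by scintillation counting, with a stated time of 10 min; on this read-out higher numbers stand for weaker inhibition and lower numbers for stronger inhibition. Of the compounds shown here, two have been measured. Compound 1 `CCCCCCCCS(=O)(=O)Nc1cc(-c2ccc(O)cc2)ccc1C(=O)O` gives 64800 nM in this assay, and compound 2 `CCCCCCCCS(=O)(=O)Nc1ccc(-c2ccc(Cl)cc2)cc1C(=O)O` gives 9200 nM. Compound 2 holds the lower of the two numbers, and its gap to compound 1 lies beyond the usual scatter, so compound 2 counts as the stronger inhibitor of the pair.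

The next compound, compound 3 `CCCCCCCCS(=O)(=O)Nc1ccc(-c2cccc(F)c2)cc1C(=O)O`, has not yet been measured. It differs from compound 2 in one place: 3-fluorophenyl in place of 4-chlorophenyl on an aromatic carbon. For the measured compounds named here, no measured step of this kind exists among the compounds seen so far, so its effect cannot be read off from the data. Compound 3 is expected to show a modest step toward a higher number, a 1.6-fold higher number from compound 2 to compound 3 (0.21 log units; within the scatter), with the outcome plausibly still within scatter. The estimate for compound 3 in this assay is 15000 nM, with a range from 6000 nM to 40000 nM.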

Compound 3, half-maximal inhibitory concentration: 37600 nM
Beside the measured number, compound 3's estimate is 2.5-fold (0.40 log units) below it; the range from low to high includes it.
By their numbers in this assay, from the lowest: compound 2; then compounds 3 and 1 (each within the scatter of the next).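

In this assay, for the compounds shown here, a 4.1-fold higher number from compound 2 to compound 3 (0.61 log units; beyond the scatter) is the only step available between compounds that differ in one place, and it shows that the number responds to a change in this aryl group. The exchange of 4-chlorophenyl for 3-fluorophenyl, on an aromatic carbon meta to a carboxy group and para to a large group, leaves the heavy-atom count, the ring and the hydrogen-bond donor and acceptor counts unchanged, so those counts do not account for the step. The halogen and its place on the ring change together here, and no measurement at hand explains the step.

On these data alone, whether the halogen or its place matters more stays open, and 4-fluorophenyl or 3-chlorophenyl would separate the two. As far as these compounds go, how an unsubstituted phenyl or a 4-methoxyphenyl group would compare also stays open.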